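Methoxy for Methyl at the Cytotoxicity Ceiling

The compounds below may be only part of what the source reports. "The series", "measured", "known", "first", "only" and "open" are said of these compounds alone.

In an ADME assay on Huh-7 cells (Homo sapiens) for cytotoxicity, read by a luciferase reporter and WST assay, with a stated time of 3 days (on this read-out higher numbers stand for lower toxicity in this test and lower numbers for higher toxicity in this test), compound 1, `O=C(Nc1ccccc1)c1c(NO)cc(-c2ccccc2)oc1=O`, gives 11600 nM. Compound 2, `O=C(Nc1ccccc1)c1c(NO)cc(-c2ccc(F)cc2)oc1=O`, gives 10300 nM in this assay, so that a 1.1-fold lower number from compound 1 to compound 2 (0.05 log units; within the scatter). Compound 3, `Cc1ccc(-c2cc(NO)c(C(=O)Nc3ccccc3)c(=O)o2)cc1`, yields only a limit in this assay, namely > 20000 nM. Compound 3 thus stands at the limit of > 20000 nM in this assay, at which 1 of the 3 values shown sits. Toward it, an at least 1.7-fold higher number from compound 1 to compound 3 (0.23 log units; that floor lies within the scatter) and an at least 1.9-fold higher number from compound 2 to compound 3 (0.28 log units; that floor lies within the scatter); both steps end at the limit, so the true gap is unknown. Compound 4, `COc1ccc(-c2cc(NO)c(C(=O)Nc3ccccc3)c(=O)o2)cc1`, differs from compound 3 by methoxy in place of methyl on an aromatic carbon. Within the data shown here, no measured step exchanges one small group on that ring for another, and the steps into compound 3 only show the number reaching the limit. The step is expected to be a step that the limit leaves unreadable from compound 3 to compound 4. Compound 4 is therefore estimated at 25000 nM, with a range from 12000 nM to 50000 nM, most likely reported again as a limit.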

Compound 4, half-maximal cytotoxic concentration: 16200 nM
Estimate against measurement, compound 4: 1.5-fold (0.19 log units) above; the measured number falls inside the stated range.
By their numbers in this assay, from the lowest: compounds 2, 1 and 4 (each within the scatter of the next). At a limit, above all of these: compound 3.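

In this assay, methoxy on this ring gives a number rather than a limit, and the change from 4-methylphenyl to 4-methoxyphenyl reads as an at least 1.2-fold lower number from compound 3 to compound 4 (0.09 log units; that floor lies within the scatter). On these data alone, compound 3 stands at a limit of the assay, > 20000 nM, so the true size of that step stays unknown. Methoxy does not separate from hydrogen or fluoro at this position, with a 1.4-fold higher number from compound 1 to compound 4 (0.15 log units; within the scatter) and a 1.6-fold higher number from compound 2 to compound 4 (0.20 log units; within the scatter).

Among these compounds, it stays open whether methyl is the only group here that reaches the limit. As far as these compounds go, how an amine, a carboxylic acid or a longer chain such as ethoxy would read at this position also remains open.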